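Ethoxycarbonyl in place of cyano on the shared core

A few compounds are considered here, and "the series" means these few. Any claim that something is new, unique, unknown or untested is made for them only; others in the source may bear on it.

Compound 3 `N#Cc1cc(=O)oc2cc(OCc3cccc(Cl)c3)ccc12` gives 102 nM in an assay on isolated protein (strain Sprague-Dawley) for inhibition of Amine oxidase [flavin-containing] B (Rattus norvegicus), read by spectrophotometry, with a stated time of 5 min (a lower number here means a stronger inhibitor, a higher number a weaker inhibitor), the second highest of three numbers: compound 2 `CC(=O)c1cc(=O)oc2cc(OCc3cccc(Cl)c3)ccc12` gives 39.8 nM and compound 1 `CCOC(=O)Nc1cc(=O)oc2cc(OCc3cccc(Cl)c3)ccc12` gives 589 nM. Compound 4 `CCOC(=O)c1cc(=O)oc2cc(OCc3cccc(Cl)c3)ccc12` differs from compound 3 by ethoxycarbonyl in place of cyano on an aromatic carbon. Among the measured compounds shown here, no measured step covers this exact exchange. The nearest are a 2.6-fold higher number from compound 2 to compound 3 (0.41 log units; beyond the scatter), where another carbonyl-bearing group stood in place of cyano, and a 5.8-fold lower number from compound 1 to compound 3 (0.76 log units; beyond the scatter), where the ethoxycarbonyl sat on a nitrogen rather than directly on the ring. Because a 2.6-fold higher number from compound 2 to compound 3 (0.41 log units; beyond the scatter) was modest, compound 4 is expected to show a modest downward step a 2.0-fold lower number from compound 3 to compound 4 (0.31 log units; beyond the scatter) in this assay. Compound 4 is estimated at 50 nM, with a range of 15 nM to 200 nM.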

Compound 4, half-maximal inhibitory concentration: 417 nM
The estimate for compound 4 lay 8.3-fold (0.92 log units) below the measured number, and the stated range ends below it.
By their numbers in this assay, from the lowest: compound 2; then compound 3; then compounds 4 and 1 (each within the scatter of the next).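

In this assay, a carbonyl on this aromatic carbon does not by itself keep the low number of compound 2: ethoxy in place of methyl on the carbonyl carbon gives a 10-fold higher number from compound 2 to compound 4 (1.02 log units; beyond the scatter). Ethoxycarbonyl in place of cyano gives a 4.1-fold higher number from compound 3 to compound 4 (0.61 log units; beyond the scatter), whereas ethoxycarbonyl in place of (ethoxycarbonyl)amino gives a 1.4-fold lower number from compound 1 to compound 4 (0.15 log units; within the scatter), so those two groups cannot be separated here. No evidence on the cause of these steps is at hand.

Open, from the compounds shown here alone, is how a carboxylic acid or a primary amine on this carbon would read. Also open, going by these compounds, is whether a longer chain on the carbonyl carbon, such as propionyl, stays close to acetyl.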